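A few compounds are considered here, and "the series" means these few. Any claim that something is new, unique, unknown or untested is made for them only; others in the source may bear on it.

The measured compounds in a functional assay on HT-29 cells (Homo sapiens) for inhibition, read by sulforhodamine B assay, with a stated time of 48 h; on this read-out higher numbers stand for weaker inhibition of growth and lower numbers for stronger inhibition of growth:

compound 1, `COc1ccc(/C=N/NC(=S)NC(C)(C)[C@H]2CC=C(C)CC2)cc1`: 8400 nM
compound 2, `COc1cc(/C=N/NC(=S)NC(C)(C)[C@H]2CC=C(C)CC2)ccc1O`: < 40 nM
compound 3, `CC1=CC[C@H](C(C)(C)NC(=S)N/N=C/c2cccc([N+](=O)[O-])c2)CC1`: 600 nM

Of the two values that are actual numbers, compound 1 stands highest in this assay, and compound 3 gives the lower number, with the gap between them lying beyond the usual scatter. Compound 2 sits at the limit of < 40 nM in this assay, at which 1 of the 3 values shown sits, so for compound 2 only a limit and no number is known. No two of these measured compounds differ in just one place, so no single measured step can be read off.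

Compound 4, `CC1=CC[C@H](C(C)(C)NC(=S)N/N=C/c2cccs2)CC1`, has not yet been measured in this assay. It differs from compound 1 in one place: thiophen-2-yl in place of 4-methoxyphenyl on a carbon with a double bond to nitrogen. Among the compounds with values here, since no measured pair carries this change, the expectation for compound 4 rests on compound 1 alone, which gives 8400 nM as its starting point. The step is expected to be a 2.1-fold lower number from compound 1 to compound 4 (0.32 log units; beyond the scatter), toward a lower number, though a step that stays within the scatter is also quite possible. Compound 4 is therefore estimated to give 4000 nM, with a range from 800 nM to 20000 nM.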

Compound 4, concentration for 50% growth inhibition: 17800 nM
The estimate for compound 4 lay 4.5-fold (0.65 log units) below the measured number, and the stated range covers the measured number.
By their numbers in this assay, from the lowest: compound 3; then compound 1; then compound 4. At a limit, below all of these: compound 2.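

Within the data shown here, the exchange of 4-methoxyphenyl for thiophen-2-yl, on a carbon with a double bond to nitrogen, gives in this assay a 2.1-fold higher number from compound 1 to compound 4 (0.33 log units; beyond the scatter), and this is the first single change that can be read. It shows that a five-membered aromatic ring with one hetero atom in place of a six-membered aromatic ring of carbon only shifts the read-out modestly toward weaker inhibition of growth, so this exchange brings no gain at this place. Nothing in the data shown offers a cause for this step.

The compounds shown do not separate the change of ring size, the entry of sulfur and the loss of the methoxy group from one another, a question that phenyl or furan-2-yl at this place would bear on. From the compounds shown here alone, how a thiophene ring carrying a methoxy group, a hydroxyl group or an amine would read in this assay also stays open.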